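A few compounds are considered here, and "the series" means these few. Any claim that something is new, unique, unknown or untested is made for them only; others in the source may bear on it.

Measured so far in an assay on isolated protein for inhibition of Dihydrofolate reductase (Homo sapiens), read by spectrophotometry, using NADPH, with stated times of 5 s and 6 min, tested at 5 uM; a lower number here means a weaker effect, a higher number a stronger effect of the compound at the concentration tested:
- compound 1 `NC1=NC2(CCSCC2)N(OCCCOc2cccc(Cl)c2Cl)C(N)=N1`: 83.8%
- compound 2 `NC1=NC2(CCOCC2)N(OCCCOc2cccc(Br)c2)C(N)=N1`: 86.7%
- compound 3 `Cc1ccc(OCCCON2C(N)=NC(N)=NC23CCOCC3)cc1`: > 90%

For compound 3 the figure in this assay is a limit of the assay, not a number; (the limit of > 90% in this assay, at which 1 of the 3 values shown sits). Of the two numbers given, compound 1 carries the lower one, with compound 2 near it within the usual scatter, so the two are not ordered.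

Compound 4 `NC1=NC2(CCSCC2)N(OCCCOc2ccc(Cl)cc2)C(N)=N1` is still to be measured. It differs from compound 1 in one place: 4-chlorophenyl in place of 2,3-dichlorophenyl on an oxygen on a saturated carbon. Among the measured compounds shown here, the only measured step that swaps the aryl group at this same position is a number at least 3.3 percentage points higher from compound 2 to compound 3 (that floor lies within the scatter), and it ends at a limit, so it tells only that such a swap did not lower the read-out; the size of its effect beyond the scatter is not known. For the measured compounds named here, no step exchanges one chlorophenyl pattern for another.

On this basis compound 4 is expected to sit near compound 1, with a step of about a number 1.2 percentage points higher from compound 1 to compound 4 (within the scatter) that is expected to stay within the scatter. The estimate for compound 4 in this assay is 85%, with a range from 72% to 92%.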

Compound 4, a percentage reported as inhibition, at one concentration (the size of the read-out at that concentration, not a potency): > 90%
Compound 4 gave a limit, no number; the forecaster's own chance of this, stated with the estimate: 25%; at least 5 percentage points between middle value and limit.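

In this assay, 4-chlorophenyl in place of 2,3-dichlorophenyl gives a number at least 6.2 percentage points higher from compound 1 to compound 4 (that floor lies within the scatter). From the compounds shown here alone, for compound 4, the reading of > 90% is a limit of the assay and not a number, so the step may or may not pass the scatter, and its true size is unknown. This is a second aryl swap on an oxygen on a saturated carbon, now on the core of compound 1, and it shows that a chlorophenyl with one chlorine instead of two did not lower the read-out, with a further compound at the top of the range: the limit of > 90% in this assay, at which 2 of the 4 values shown sit.

Going by these compounds, compounds that reach the limit cannot be ordered among themselves, so the preferred aryl group at this place stays open. Also open, on these data alone, is how the read-out responds to a pyridine ring, a carboxylic acid on the phenyl ring, or a longer chain before the aryl group.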